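The source may report more compounds than this note shows. Statements on the series, on what has been measured and on what is new or still open speak of the compounds shown alone.

Compounds measured so far:
Compound 1, `CCCCNc1nc(N)nc(C)c1CCCc1ccccc1`: 749 nM
Compound 2, `CCCCNc1nc(N)nc(C)c1CCCN1CCCC1`: 110 nM
Compound 3, `CCCCNc1nc(N)nc(C)c1CCCN(C)C`: 126 nM

In an assay on HEK293 cells for agonist activity at Toll-like receptor 8 (Homo sapiens), read by spectrophotometry (on this read-out lower numbers stand for an effect already at smaller amounts and higher numbers for an effect only at larger amounts of compound), compound 3 stands second highest of the three numbers. Its nearest neighbour is compound 2, and the step of a 1.1-fold higher number from compound 2 to compound 3 (0.06 log units; within the scatter) lies within the scatter, so no order between the two can be claimed. The step of a 5.9-fold lower number from compound 1 to compound 3 (0.77 log units; beyond the scatter) is beyond the scatter and shows that the amine-bearing chain end of compound 3 is linked to a clearly lower number than the phenyl-bearing chain end of compound 1.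

Compound 4, `CCCCNc1nc(N)nc(C)c1CCCCCc1ccccc1`, is yet to be measured. It differs from compound 3 in one place: phenethyl in place of dimethylamino on a saturated chain carbon, three bonds along the chain from an aromatic carbon. Going by the values given here, the steps that bear on this change are a 5.9-fold lower number from compound 1 to compound 3 (0.77 log units; beyond the scatter) and a 6.8-fold lower number from compound 1 to compound 2 (0.83 log units; beyond the scatter), both modest, both running from a phenyl-ended chain to an amine-ended chain and both lowering the number. Among the compounds with values here, compound 4 reverses that direction, though with a longer chain to the phenyl, for which no measured compound offers a comparison. The expected outcome is therefore a modest rise in number, a 7.1-fold higher number from compound 3 to compound 4 (0.85 log units; beyond the scatter). Compound 4 is estimated at 900 nM, within a range of 300 nM to 3000 nM.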

Compound 4, half-maximal effective concentration: 830 nM
Compound 4: middle estimate off by 1.1-fold (0.04 log units), on the high side; the range from low to high includes it.
By their numbers in this assay, from the lowest: compounds 2 and 3 (each within the scatter of the next); then compounds 1 and 4 (each within the scatter of the next).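

In this assay the phenethyl group of compound 4 gives a clearly higher number than either amine-ended chain, with a 6.6-fold higher number from compound 3 to compound 4 (0.82 log units; beyond the scatter) and a 7.5-fold higher number from compound 2 to compound 4 (0.88 log units; beyond the scatter). The link between a phenyl-ended chain and a higher number, until now resting on compound 1 alone, therefore also holds for a second, longer chain. Against compound 1, a 1.1-fold higher number from compound 1 to compound 4 (0.04 log units; within the scatter) shows that the longer chain to the phenyl cannot be told apart from the shorter one in these two compounds.

The compounds shown leave open whether a dimethylamino or pyrrolidin-1-yl group at the end of the longer chain of compound 4 would match compounds 2 and 3, and where a carboxylic acid at the chain end would fall. No measured evidence is available to explain these steps.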